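The source may report more compounds than this note shows. Statements on the series, on what has been measured and on what is new or still open speak of the compounds shown alone.

Compound 2 `CC1=CC[C@H](C(C)(C)NC(=S)N/N=C/c2ccco2)CC1` gives 9300 nM in a functional assay on MCF7 cells (Homo sapiens) for inhibition, read by sulforhodamine B assay, with a stated time of 48 h (on this read-out lower numbers stand for stronger inhibition of growth and higher numbers for weaker inhibition of growth), and stands together with compound 1 `CC1=CC[C@H](C(C)(C)NC(=S)N/N=C/c2ccccc2)CC1`, which gives 8400 nM, the gap between the two lying within the scatter. Going by the values given here, the one measured step, a 1.1-fold higher number from compound 1 to compound 2 (0.04 log units; within the scatter), also exchanges the group on the carbon with a double bond to nitrogen and stays within the scatter. Compound 3 `CC1=CC[C@H](C(C)(C)NC(=S)N/N=C/c2ccc[nH]2)CC1` carries the change (1H-pyrrol-2-yl in place of furan-2-yl on a carbon with a double bond to nitrogen), one five-membered aromatic ring for another at the same place. On that precedent no step beyond the scatter is expected in this assay. Compound 3 is therefore estimated at 9000 nM, within 4000 nM to 20000 nM, a step of a 1.0-fold lower number from compound 2 to compound 3 (0.01 log units; within the scatter).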

Compound 3, concentration for 50% growth inhibition: 3900 nM
Estimate against measurement, compound 3: 2.3-fold (0.36 log units) above; the measured number lies below the stated range.
By their numbers in this assay, from the lowest: compound 3; then compounds 1 and 2 (each within the scatter of the next).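

At the carbon with a double bond to nitrogen, the choice of ring now matters in this assay: 1H-pyrrol-2-yl gives a 2.4-fold lower number from compound 2 to compound 3 (0.38 log units; beyond the scatter) and also a 2.2-fold lower number from compound 1 to compound 3 (0.33 log units; beyond the scatter) and both steps are modest but beyond the scatter, whereas furan-2-yl in place of phenyl stayed within it. Swapping one five-membered aromatic ring for another at this place is therefore not always neutral. Nothing available explains the step. Open, going by these compounds, is whether a thiophene ring, or a pyrrole ring with a methyl group on its nitrogen, would match compound 3 or instead compound 1 and compound 2.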